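Swapping Bromo for Chloro: A Cell Toxicity Estimate

The source may report more compounds than this note shows. Statements on the series, on what has been measured and on what is new or still open speak of the compounds shown alone.

Compound 1 `CCOc1ccc(/C=N/NC(=O)COc2cccc3ccccc23)cc1O` measured at 18.1 ug/mL
Compound 2 `O=C(COc1cccc2ccccc12)N/N=C/c1ccccc1Br` measured at 100 ug/mL
Compound 3 `C/C(=N\NC(=O)COc1cccc2ccccc12)c1ccccc1` measured at 20 ug/mL

All three compounds were tested in an ADME assay on HEL cells (Homo sapiens) for cytotoxicity (on this read-out higher numbers stand for lower toxicity in this test and lower numbers for higher toxicity in this test), and share one core. Compound 2, at 100 ug/mL, holds the highest number of the three, and the gaps to compound 1 and compound 3 both lie beyond the usual scatter. It is therefore the least toxic of the three in this test.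

The next compound to be measured is compound 4 `O=C(COc1cccc2ccccc12)N/N=C/c1ccccc1Cl`, which differs from compound 2 in one place: chloro in place of bromo on an aromatic carbon. This puts chloro in place of bromo on an aromatic carbon, ortho to a large group. Going by the values given here, no measured pair shows this swap, or any other single change, so the data offer no direct guide. In this assay, no step beyond the scatter is expected, with a slight lean towards a lower number since compound 2 stands at the top with 100 ug/mL for this small set. The expected change is a 1.4-fold lower number from compound 2 to compound 4 (0.15 log units; within the scatter) for this swap. For compound 4 the estimated value is 70 ug/mL, with an expected range from 25 ug/mL to 100 ug/mL as its limits.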

Compound 4, half-maximal cytotoxic concentration: 62.7 ug/mL
The estimate for compound 4 lay 1.1-fold (0.05 log units) above the measured number; measured number inside the range.
By their numbers in this assay, from the lowest: compounds 1 and 3 (each within the scatter of the next); then compounds 4 and 2 (each within the scatter of the next).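

Chloro in place of bromo on an aromatic carbon, ortho to a large group, gives a 1.6-fold lower number from compound 2 to compound 4 (0.20 log units; within the scatter) in this assay and so provides the first direct reading of a single change in this set. The step from 2-bromophenyl to 2-chlorophenyl cannot be told apart from the normal variation between repeated measurements, so this test does not separate the two groups at this position. Nothing available here offers an explanation for this result.

The compounds shown leave open whether a group of a different kind at this position, such as an amine, a carboxylic acid or a longer chain, would also leave the number within the scatter. They also leave open whether the same swap of bromo for chloro would give a similar step on a different core.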